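A few compounds are considered here, and "the series" means these few. Any claim that something is new, unique, unknown or untested is made for them only; others in the source may bear on it.

Measured so far in a functional assay for inhibition of sodium/hydrogen exchanger (Oryctolagus cuniculus); on this read-out higher numbers stand for weaker inhibition and lower numbers for stronger inhibition:
compound 1 `Cc1cc(C2CCCCC2)c(S(C)(=O)=O)cc1C(=O)N=C(N)N` gives 22 nM
compound 2 `Cc1cc(-c2cc(Cl)cc(Cl)c2)c(S(C)(=O)=O)cc1C(=O)N=C(N)N` gives 130 nM

Among the measured compounds shown here, compound 2 stands with the higher of the two numbers, its nearest neighbour being compound 1; the single measured step is a 5.9-fold higher number from compound 1 to compound 2 (0.77 log units; beyond the scatter). Compound 3 `Cc1cc(SC(C)C)c(S(C)(=O)=O)cc1C(=O)N=C(N)N` differs from compound 2 by isopropylsulfanyl in place of 3,5-dichlorophenyl on an aromatic carbon. For the measured compounds named here, no measured step covers this exact exchange; the only step that bears on it, a 5.9-fold higher number from compound 1 to compound 2 (0.77 log units; beyond the scatter), shows that the 3,5-dichlorophenyl group leaving here went with a modest rise when it entered. A modest fall beyond the scatter is therefore expected, with the step of a 3.3-fold lower number from compound 2 to compound 3 (0.51 log units; beyond the scatter) taken as the estimate. Compound 3 is estimated at 40 nM, within 10 nM to 160 nM.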

Compound 3, half-maximal inhibitory concentration: 12 nM
Compound 3: middle estimate off by 3.3-fold (0.52 log units), on the high side; the measured number falls inside the stated range.
By their numbers in this assay, from the lowest: compounds 3 and 1 (each within the scatter of the next); then compound 2.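

In this assay, replacing 3,5-dichlorophenyl with isopropylsulfanyl on this aromatic carbon, ortho to the methylsulfonyl group, gives a large gain (an 11-fold lower number from compound 2 to compound 3 (1.03 log units; beyond the scatter)). This shows that a smaller group without a ring can match the cyclohexyl group here, as exchanging cyclohexyl for isopropylsulfanyl stays within the scatter (a 1.8-fold lower number from compound 1 to compound 3 (0.26 log units; within the scatter)). No available evidence accounts for either step.

The compounds shown leave open whether the sulfur matters, which an isopropoxy or plain isopropyl group at this place would test. Also open, going by these compounds, is whether an amine or a carboxylic acid is tolerated here.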